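Exchanging the aryl group on a ring amine nitrogen

The compounds below may be only part of what the source reports. "The series", "measured", "known", "first", "only" and "open" are said of these compounds alone.

Measured so far:
compound 1 `CCCc1nc(-c2ccccc2)c(CNCCCN2CCN(c3cccc(OC)c3)CC2)o1`: 36.4%
compound 2 `CCCc1nc(-c2ccccc2)c(CNCCCN2CCN(c3ccccc3Cl)CC2)o1`: 64.7%

In an assay on HEK293 cells for inhibition of Voltage-dependent T-type calcium channel subunit alpha-1G (Homo sapiens), read by fluorescence, tested at 10 uM (a lower number here means less inhibition, a higher number more inhibition at the concentration tested (going by the name of the read-out)), compound 1 gives 36.4%, while compound 2 gives 64.7%. Among the compounds with values here, compound 2 thus stands highest of the two numbers, and the single measured step, a number 28.3 percentage points higher from compound 1 to compound 2 (beyond the scatter), lies beyond the scatter. Compound 3 `CCCc1nc(-c2ccccc2)c(CNCCCN2CCN(c3ccc(C)c(C)c3)CC2)o1` has not yet been measured in this assay. Its change from compound 2 is 3,4-dimethylphenyl in place of 2-chlorophenyl on an amine nitrogen in a ring. Within the data shown here, no measured step bears directly on this exchange: the only step available, from compound 1 to compound 2, replaced a 3-methoxyphenyl, not a 3,4-dimethylphenyl, so it gives direction only loosely. Given that both measured values fall in the middle of the range, the writer expects compound 3 to move by a number 12.7 percentage points lower from compound 2 to compound 3 (beyond the scatter), a modest downward step that may still sit within the scatter. The estimate for compound 3 in this assay is 52%, expected to fall between 28% and 76%.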

Compound 3, a percentage reported as inhibition, at one concentration (the size of the read-out at that concentration, not a potency): 54.6%
Compound 3: the middle estimate sits 2.6 percentage points below what was measured; low and high end bracket the measured number.
By their numbers in this assay, from the lowest: compound 1; then compound 3; then compound 2.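

In this assay the 3,4-dimethylphenyl group gives a number that falls on both sides of a step: a number 10.1 percentage points lower from compound 2 to compound 3 (beyond the scatter) and a number 18.2 percentage points higher from compound 1 to compound 3 (beyond the scatter). The aryl group on this ring nitrogen therefore sets the reading at three separate levels across the three compounds, and a phenyl ring carrying no chlorine can still give more inhibition than the 3-methoxyphenyl ring of compound 1. No measurement at hand accounts for these differences.

Since the exchange from compound 2 to compound 3 alters both the substituents and where they stand on the phenyl ring, the compounds shown do not separate these two changes. Going by these compounds, how an unsubstituted phenyl, a 3-chlorophenyl or a 4-methylphenyl group would read on the same nitrogen remains open.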